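The source may report more compounds than this note shows. Statements on the series, on what has been measured and on what is new or still open speak of the compounds shown alone.

In an assay on isolated protein for inhibition of alpha-ketoglutarate-dependent dioxygenase alkB homolog 3 (Homo sapiens), read by polymerase chain reaction, with a stated time of 1 h (a higher number here means a weaker inhibitor, a lower number a stronger inhibitor), two compounds have been measured so far:

Compound 1, `Cc1ccc2[nH]c(-n3nc(-c4ccccc4)c(-c4ccccc4)c3O)nc2c1`: 5800 nM
Compound 2, `Cc1[nH]n(-c2nc3cc(C(C)(C)C)ccc3[nH]2)c(=O)c1Cc1ccccc1`: 640 nM

Compound 2 gives the lower of the two numbers, and the gap to compound 1 lies beyond the usual scatter, so compound 2 is the stronger inhibitor of the pair. Compound 3, `Cc1ccc2[nH]c(-n3[nH]c(C)c(Cc4ccccc4)c3=O)nc2c1`, has not yet been measured. It keeps the core of compound 2 and changes one group: methyl in place of tert-butyl on an aromatic carbon. For the measured compounds named here, no measured pair in this set isolates that change, so there is nothing here to anchor its effect; the two measured compounds differ in more than one place at once. A small shift toward a weaker inhibitor seems the most likely outcome, though a step that stays within the scatter would not be surprising. The expected step is a 2.0-fold higher number from compound 2 to compound 3 (0.31 log units; beyond the scatter). Compound 3 is therefore estimated at 1300 nM, in a range from 450 nM to 4000 nM.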

Compound 3, half-maximal inhibitory concentration: 670 nM
For compound 3 the middle estimate is 1.9-fold (0.29 log units) above the measured one; measured number inside the range.
By their numbers in this assay, from the lowest: compounds 2 and 3 (each within the scatter of the next); then compound 1.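

In this assay, for the compounds shown here, the first pair that differs in one place shows a 1.0-fold higher number from compound 2 to compound 3 (0.02 log units; within the scatter) when methyl stands in place of tert-butyl on this aromatic carbon. Compounds 2 and 3 therefore cannot be told apart in this assay, although the group that leaves has 4 heavy atoms and the one that enters has 1. At this position, in these two compounds, the size of the carbon group makes no difference that can be read, and nothing available here accounts for that result.

Only methyl and tert-butyl are shown at this carbon, so it remains open how an amine, a carboxylic acid or a longer chain would behave there. On these data alone, it is also open whether the same holds when other parts of the core differ.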